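This account rests on a few compounds, and the source may have more. Where it says the series, first, only, none or still open, it means among the compounds named here.

Compound 3 `O=C(NC(=S)N1CCc2c(OCCCCCOc3ccc(Cl)cc3)cccc21)c1cc2ccccc2s1` shares its core with compound 1 `O=C(NC(=S)N1CCc2c(OCCCCCOc3ccc(Cl)cc3)cccc21)c1ccc2ccccc2c1` and compound 2 `O=C(NC(=S)N1CCc2c(OCCCCCOc3ccc(Cl)cc3)cccc21)c1ccno1`; the three differ only in the group on the carbonyl carbon. In an ADME assay on Huh-7 cells (Homo sapiens) for cytotoxicity (on this read-out higher numbers stand for lower toxicity in this test and lower numbers for higher toxicity in this test), compound 3 reaches only a limit of the assay, > 50000 nM. Compound 1 likewise reaches only a limit there, > 50000 nM. Compound 2 gives a number in this assay, 37100 nM. The steps among the three are accordingly small or unreadable: an at least 1.3-fold lower number from compound 1 to compound 2 (0.12 log units; that floor lies within the scatter), an at least 1.3-fold higher number from compound 2 to compound 3 (0.12 log units; that floor lies within the scatter), and a step that the two limits leave unreadable from compound 1 to compound 3. Compound 3 therefore stands at the edge of what this assay can report, a position it shares with compound 1 (the limit of > 50000 nM in this assay, at which 2 of the 3 values shown sit).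

Compound 4 `O=S(=O)(NC(=S)N1CCc2c(OCCCCCOc3ccc(Cl)cc3)cccc21)c1ccccc1` carries a change of another kind: phenylsulfonyl in place of (1-benzothiophen-2-yl)carbonyl on an amide-type nitrogen. Among the measured compounds shown here, none of the measured steps touches this place; all three concern the group on the carbonyl carbon, and each was within the scatter or unreadable. On that basis no step beyond the scatter is expected in this assay from compound 3 to compound 4. Compound 4 is estimated at 50000 nM, between 25000 nM and 100000 nM. That estimate means an expected step of a number no higher from compound 3 to compound 4 (the limit leaves the size open) in this assay.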

Compound 4, half-maximal cytotoxic concentration: > 50000 nM
Compound 4 was reported as a limit (the forecaster's own chance of this, stated with the estimate: 60%); the middle value sits exactly at the limit.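

In this assay compound 4 gives > 50000 nM, which is a limit and not a number, so this first change shown at the amide-type nitrogen, to phenylsulfonyl in place of a carbonyl-linked group, leaves the compound at the same edge of the read-out: the limit of > 50000 nM in this assay, at which 3 of the 4 values shown sit.

Among the compounds shown here, the one step that can be read is an at least 1.3-fold higher number from compound 2 to compound 4 (0.12 log units; that floor lies within the scatter), so the change to the sulfonyl group shows no difference beyond the scatter here. The steps to compound 4 from compound 1 and from compound 3 cannot be read, since both ends of each are limits.

The true values of compound 1, compound 3 and compound 4 lie outside what this assay reports, which leaves open whether the phenylsulfonyl and carbonyl-linked compounds differ at all. Also open, as far as these compounds go, is how the read-out would respond to a methylsulfonyl group at this nitrogen or to a carboxylic acid on the phenyl ring of the phenylsulfonyl group.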